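Swapping the sulfonyl aryl of a bromobenzyl hexanediamine sulfonamide

This account rests on a few compounds, and the source may have more. Where it says the series, first, only, none or still open, it means among the compounds named here.

In a functional assay on MIA PaCa-2 cells (Homo sapiens) for inhibition, read by MTT assay, with a stated time of 72 h (on this read-out lower numbers stand for stronger inhibition of growth and higher numbers for weaker inhibition of growth), the measured compounds gave the following numbers:
Compound 1, `COc1ccc(S(=O)(=O)NCCCCCCNCc2ccc(Br)cc2)cc1`: 13000 nM
Compound 2, `O=S(=O)(NCCCCCCNCc1ccc(Br)cc1)c1cc(Cl)cc(Cl)c1`: 12000 nM
Compound 3, `O=S(=O)(NCCCNCC1COc2ccccc2O1)c1cc(C(F)(F)F)cc(C(F)(F)F)c1`: 2600 nM

Compound 2 stands second highest of the three numbers in this assay. Its nearest neighbour is compound 1, whose number is within the scatter of it, and its furthest is compound 3, which carries a different linker and amine part and gives a number beyond the scatter lower than that of compound 2. Going by the values given here, no step between compound 2 and compound 3 is recorded, so only the two values themselves can be compared.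

Compound 4, `O=S(=O)(NCCCCCCNCc1ccc(Br)cc1)c1ccccc1F`, is not yet measured. It differs from compound 2 in one place: 2-fluorophenyl in place of 3,5-dichlorophenyl on a sulfonyl sulfur. Among the compounds with values here, the one recorded step that bears on this change is the exchange of the aryl group on the same sulfonyl sulfur, a 1.1-fold lower number from compound 1 to compound 2 (0.03 log units; within the scatter). That step stayed within the scatter, so for compound 4 no step beyond the scatter is expected in this assay in either direction. The estimated step of a 1.1-fold higher number from compound 2 to compound 4 (0.03 log units; within the scatter) is therefore small. Compound 4 is thus expected to give about 13000 nM in this assay, with a range from 5000 nM to 35000 nM.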

Compound 4, concentration for 50% growth inhibition: 13300 nM
Compound 4: middle estimate off by 1.0-fold (0.01 log units), on the low side; the measured number falls inside the stated range.
By their numbers in this assay, from the lowest: compound 3; then compounds 2, 1 and 4 (each within the scatter of the next).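

Across the aryl groups on the sulfonyl sulfur of this shared core, the picture in this assay now rests on three groups rather than one exchange: 2-fluorophenyl in place of 3,5-dichlorophenyl gives a 1.1-fold higher number from compound 2 to compound 4 (0.04 log units; within the scatter) as its step, and 2-fluorophenyl in place of 4-methoxyphenyl gives a 1.0-fold higher number from compound 1 to compound 4 (0.01 log units; within the scatter) as its step. Compound 1, compound 2 and compound 4 therefore stand within the scatter of one another, although the aryl group carries a methoxy group, two chlorines or one fluorine, so for these three compounds neither the kind nor the number of these substituents separates the values. Nothing available here accounts for how close these numbers lie.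

On these data alone, whether this insensitivity extends to aryl groups carrying a carboxylic acid or an amine, or to a sulfonyl sulfur bearing a plain alkyl chain instead of an aryl group, stays open. Also open, as far as these compounds go, is whether the 3,5-bis(trifluoromethyl)phenyl group of compound 3 would give a number on the bromobenzyl hexanediamine core that stands apart from these three.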